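This account rests on a few compounds, and the source may have more. Where it says the series, first, only, none or still open, it means among the compounds named here.

In a functional assay on the whole organism (strain Wistar) for inhibition, with Rattus norvegicus as the target, read by paw edema, with stated times of 60 min and 1 h, at a dose of 100 mg/kg by the oral route (a higher number here means more inhibition at the dose given (going by the name of the read-out), a lower number less inhibition), compound 1 `CCN(CC)C(=O)CC1CCc2cc(OC)c(OC)cc21` gives 31.3%, the second highest of the three numbers measured. Compound 2 `CCCCCCNC(=O)CC1CCc2cc(OC)c(OC)cc21` gives 47.6% and compound 3 `COc1cc2c(cc1OC)C(CC(=O)N1CCCC1)CC2` gives 4.69%. The two steps leading from compound 1 are a number 16.3 percentage points higher from compound 1 to compound 2 (beyond the scatter) and a number 26.6 percentage points lower from compound 1 to compound 3 (beyond the scatter); between the other pair the step is a number 42.9 percentage points lower from compound 2 to compound 3 (beyond the scatter). Compound 4 `COc1cc2c(cc1OC)C(CC(=O)N1CCOCC1)CC2` differs from compound 1 as follows.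

morpholin-4-yl in place of diethylamino on a carbonyl carbon

Going by the values given here, the step that bears most on this change is the one to compound 3, where pyrrolidin-1-yl took the place of diethylamino on the carbonyl carbon and inhibition fell well beyond the scatter. A fall of similar kind is therefore expected for compound 4, about a number 19.3 percentage points lower from compound 1 to compound 4 (beyond the scatter). Compound 4 is estimated at 12%, with a range from 0% to 30%.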

Compound 4, a percentage reported as inhibition, in the whole organism at one dose (the size of the read-out at that dose, not a potency): 15.6%
Estimate against measurement, compound 4: 3.6 percentage points below, within the range that was stated.
By their numbers in this assay, from the lowest: compound 3; then compound 4; then compound 1; then compound 2.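

In this assay, a second ring on the carbonyl carbon also lowers inhibition relative to diethylamino, with a number 15.7 percentage points lower from compound 1 to compound 4 (beyond the scatter) (so the fall is not confined to pyrrolidin-1-yl). The two rings also differ from each other, with a number 10.9 percentage points higher from compound 3 to compound 4 (beyond the scatter) (and hexylamino stays well ahead, with a number 32 percentage points lower from compound 2 to compound 4 (beyond the scatter)). Nothing available explains these differences.

Piperidin-1-yl would show where a ring without the oxygen falls relative to these two. Butylamino and methylhexylamino would help separate the effect of chain length from that of the amide hydrogen in compound 2.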